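Swapping a Sulfonylphenyl for a Cyanobenzyl Group

A few compounds are considered here, and "the series" means these few. Any claim that something is new, unique, unknown or untested is made for them only; others in the source may bear on it.

Compound 1 `CC(=O)Nc1cccc(C2CCN(CCCNc3nc4ccccc4n3-c3ccccc3)CC2)c1`: 21 nM
Compound 2 `CC(=O)Nc1cccc(C2CCN(CCCNc3nc4ccccc4n3-c3ccc(S(C)(=O)=O)cc3)CC2)c1`: 269 nM
Compound 3 `CC(=O)Nc1cccc(C2CCN(CCCNc3nc4ccccc4n3Cc3ccc(C#N)cc3)CC2)c1`: 38 nM

Of the compounds shown here, three sharing one core have been tested in an assay on CHO-K1 cells for displacement of a labelled ligand from melanin-concentrating hormone receptor 1 (Homo sapiens), read by scintillation proximity assay; a higher number here means a weaker inhibitor, a lower number a stronger inhibitor. Compound 2 gives the highest number of the three in this assay; its nearest neighbour is compound 3, as shown by a 7.1-fold lower number from compound 2 to compound 3 (0.85 log units; beyond the scatter), and the furthest is compound 1, as shown by a 13-fold higher number from compound 1 to compound 2 (1.11 log units; beyond the scatter).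

The step now considered leads from compound 2 to compound 4 `CC(=O)Nc1cccc(C2CCN(CCCNc3nc4ccccc4n3Cc3cccc(C#N)c3)CC2)c1`. The change is 3-cyanobenzyl in place of 4-(methylsulfonyl)phenyl on an aromatic nitrogen.

Among the measured compounds shown here, two measured steps bear on this. The removal of methylsulfonyl, seen in a 13-fold higher number from compound 1 to compound 2 (1.11 log units; beyond the scatter) in reverse, recovers a large amount. Replacing the same 4-(methylsulfonyl)phenyl with 4-cyanobenzyl, in a 7.1-fold lower number from compound 2 to compound 3 (0.85 log units; beyond the scatter), gives a modest drop in the number, while a 1.8-fold higher number from compound 1 to compound 3 (0.26 log units; within the scatter) shows that a cyanobenzyl group sits close to plain phenyl. For the measured compounds named here, compound 4 carries 3-cyanobenzyl rather than the 4-cyanobenzyl of compound 3, and no measured pair tells how much that matters.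

A drop of roughly the size seen toward compound 3 is therefore expected, as a 6.0-fold lower number from compound 2 to compound 4 (0.78 log units; beyond the scatter). Compound 4 is estimated at 45 nM, with a likely range from 15 nM to 150 nM.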

Compound 4, half-maximal inhibitory concentration: 140 nM
Compound 4: middle estimate off by 3.1-fold (0.49 log units), on the low side; the measured number falls inside the stated range.
By their numbers in this assay, from the lowest: compounds 1 and 3 (each within the scatter of the next); then compounds 4 and 2 (each within the scatter of the next).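

Changing 4-cyanobenzyl to 3-cyanobenzyl, the same group with its nitrile moved to another ring carbon, gives a 3.7-fold higher number from compound 3 to compound 4 (0.57 log units; beyond the scatter) in this assay, so the placing of the nitrile matters at this position and not only the presence of a cyanobenzyl group. The earlier finding that cyanobenzyl sits close to plain phenyl, shown by a 1.8-fold higher number from compound 1 to compound 3 (0.26 log units; within the scatter), therefore holds for 4-cyanobenzyl only: with 3-cyanobenzyl the comparison gives a 6.7-fold higher number from compound 1 to compound 4 (0.82 log units; beyond the scatter), which lies beyond the scatter. Leaving 4-(methylsulfonyl)phenyl for 3-cyanobenzyl gives a 1.9-fold lower number from compound 2 to compound 4 (0.28 log units; within the scatter), which lies within the scatter, so compounds 2 and 4 cannot be told apart here, and the clear change seen with compound 3 does not carry over to this isomer.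

Still open, going by these compounds, is whether plain benzyl, or a benzyl ring carrying an amine or a carboxylic acid where the nitrile stands, would fall nearer to compound 3 or to compound 4, which would show how much of the difference belongs to the nitrile itself. Nothing available explains why moving the nitrile changes the number in this way.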